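A few compounds are considered here, and "the series" means these few. Any claim that something is new, unique, unknown or untested is made for them only; others in the source may bear on it.

Measured so far:
- Compound 1 `COc1ccc2c(c1)cc(-c1cc(OC)c(OC)c(OC)c1)n2Cc1ccccc1`: > 30000 nM, a limit.
- Compound 2 `COc1ccc2c(c1)cc(-c1cc(OC)c(OC)c(OC)c1)n2Cc1ccc(O)cc1`: > 30000 nM, a limit.

Both were tested in a functional assay on PC-3 cells (Homo sapiens) for cytotoxicity, read by MTT assay, with a stated time of 24 h; a higher number here means a weaker inhibitor, a lower number a stronger inhibitor. Within the data shown here, neither compound has a numerical value, and the limit of > 30000 nM in this assay, at which 2 of the 2 values shown sit, describes everything measured so far. Compound 2 therefore offers only a limit as a starting point.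

Compound 3 `COc1ccc2c(c1)c(Cc1ccc(O)cc1)c(-c1cc(OC)c(OC)c(OC)c1)n2Cc1ccc(O)cc1` keeps compound 2 unchanged except at one place: 4-hydroxybenzyl in place of hydrogen on an aromatic carbon. A 4-hydroxybenzyl group replaces hydrogen on an aromatic carbon, next to the ring atom that bears a 3,4,5-trimethoxyphenyl group.

Among the measured compounds shown here, the only measured step is a step that the two limits leave unreadable from compound 1 to compound 2. It also adds a hydroxy group, but it provides no size to carry over. For the measured compounds named here, with no readable precedent, no step of a particular size can be derived for this assay. Compound 3 is expected to remain close to the limit, and a reported limit is somewhat more likely than a number. If a number appears, it should point towards stronger inhibition, and the expected step is an at least 1.2-fold lower number from compound 2 to compound 3 (0.07 log units; that floor lies within the scatter). For compound 3 the estimated value is 25000 nM, with an expected range from 8000 nM to 50000 nM.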

Compound 3, half-maximal inhibitory concentration: > 30000 nM
Compound 3 was reported as a limit (the forecaster's own chance of this, stated with the estimate: 60%); middle value at least 1.2-fold (0.07 log units) away from the limit.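

In this assay compound 3 gives > 30000 nM, a limit. Among these compounds, compound 2 also stands at a limit, so no step from compound 2 to compound 3 can be read. The compounds shown leave open whether 4-hydroxybenzyl in place of hydrogen changes inhibition at all, since the series so far holds only one reading: the limit of > 30000 nM in this assay, at which 3 of the 3 values shown sit.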